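The compounds below may be only part of what the source reports. "The series", "measured", "known", "first", "only" and "open" are said of these compounds alone.

Among the compounds with values here, compound 3 `Cn1c(-c2ccccc2)c(C#N)c2c(N)ncnc21` stands second highest of the three numbers so far in an assay on isolated protein for binding affinity to Leucine-rich repeat serine/threonine-protein kinase 2 variant G2019S (Homo sapiens), read by TR-FRET and LanthaScreen, with a stated time of 2 h (on this read-out higher numbers stand for weaker inhibition and lower numbers for stronger inhibition), giving 33 nM. Compound 1 `CN(C)c1c(C#N)c2c(N)ncnc2n1C` gives 259 nM, and compound 2 `C[C@@H]1CCCN1c1c(C#N)c2c(N)ncnc2n1C` gives 0.7 nM; the step of a 7.8-fold lower number from compound 1 to compound 3 (0.89 log units; beyond the scatter) is modest, whereas a 370-fold lower number from compound 1 to compound 2 (2.57 log units; beyond the scatter) is large, and a 47-fold higher number from compound 2 to compound 3 (1.67 log units; beyond the scatter) runs the other way.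

Compound 4 `C[C@H]1CCCN1c1c(C#N)c2c(N)ncnc2n1C` is made from compound 3 by the change (2-methylpyrrolidin-1-yl in place of phenyl on an aromatic carbon). Within the data shown here, compound 2 carries the same 2-methylpyrrolidin-1-yl group but with the opposite configuration at its defined stereocentre, so no measured step matches compound 4 exactly. The step that bears most directly on it is the reverse of a 47-fold higher number from compound 2 to compound 3 (1.67 log units; beyond the scatter), which was large; the two enantiomers need not give the same number, and nothing shown says how far they differ.

A large drop in the number is therefore expected, and compound 4 is estimated at 8 nM, within 1 nM to 60 nM, a step of a 4.1-fold lower number from compound 3 to compound 4 (0.62 log units; beyond the scatter) from compound 3, because of the size of a 47-fold higher number from compound 2 to compound 3 (1.67 log units; beyond the scatter).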

Compound 4, inhibition constant: 212 nM
The estimate for compound 4 lay 27-fold (1.42 log units) below the measured number; the measured number lies above the stated range.
By their numbers in this assay, from the lowest: compound 2; then compound 3; then compounds 4 and 1 (each within the scatter of the next).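

In this assay, the 2-methylpyrrolidin-1-yl group does not bring strong binding by itself: a 6.4-fold higher number from compound 3 to compound 4 (0.81 log units; beyond the scatter), and a 1.2-fold lower number from compound 1 to compound 4 (0.09 log units; within the scatter), so this form of the group offers no clear gain over the small dimethylamino group. Within the data shown here, what the earlier compounds could not show is how much depends on the configuration of the saturated ring carbon. With a 300-fold higher number from compound 2 to compound 4 (2.48 log units; beyond the scatter), that one stereocentre, drawn R in the stronger binder and S in the weaker, accounts for the whole step because of this: the fact that compounds 2 and 4 differ only in the configuration as drawn.

Going by these compounds, it remains open where the unsubstituted pyrrolidin-1-yl group would fall relative to these two forms. On these data alone, it is also open whether an ethyl group in place of the methyl, or a piperidin-1-yl ring, would show the same split between configurations.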